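From Nitrophenyl to Cyanophenyl in a Cytotoxicity Series

A few compounds are considered here, and "the series" means these few. Any claim that something is new, unique, unknown or untested is made for them only; others in the source may bear on it.

In a functional assay on QGY-7703 cells (Homo sapiens) for cytotoxicity, read by MTT assay, with a stated time of 24 h (a lower number here means a stronger inhibitor, a higher number a weaker inhibitor), compound 1 `COc1cc(/C=C2\CN(S(=O)(=O)c3ccc(F)cc3)C/C(=C\c3cc(OC)c(OC)c(OC)c3)C2=O)cc(OC)c1OC` gives 2220 nM and compound 2 `COc1cc(/C=C2\CN(S(=O)(=O)c3ccc(F)cc3)C/C(=C\c3cccc([N+](=O)[O-])c3)C2=O)cc(OC)c1OC` gives 3270 nM as its value, level with compound 1 within the usual scatter. Compound 3 `COc1cc(/C=C2\CN(S(=O)(=O)c3ccc(F)cc3)C/C(=C\c3ccc(C#N)cc3)C2=O)cc(OC)c1OC` differs from compound 2 by 4-cyanophenyl in place of 3-nitrophenyl on a double-bonded chain carbon bound to a double-bonded ring carbon and carries 4-cyanophenyl in place of 3-nitrophenyl on a double-bonded chain carbon bound to a double-bonded ring carbon. For the measured compounds named here, the one measured swap at this place is a 1.5-fold higher number from compound 1 to compound 2 (0.17 log units; within the scatter) and so no step beyond the scatter is expected in this assay here. The estimate means a 1.2-fold lower number from compound 2 to compound 3 (0.07 log units; within the scatter) as the expected step. For compound 3 the estimated value is 2800 nM with 1100 nM to 7000 nM as its expected range.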

Compound 3, half-maximal inhibitory concentration: 4980 nM
For compound 3 the middle estimate is 1.8-fold (0.25 log units) below the measured one, within the range that was stated.
By their numbers in this assay, from the lowest: compounds 1, 2 and 3 (each within the scatter of the next, the first and the last beyond it).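

Swapping 3-nitrophenyl for 4-cyanophenyl at this place gives a step within the scatter (a 1.5-fold higher number from compound 2 to compound 3 (0.18 log units; within the scatter)) in this assay, so these two groups cannot be told apart here. For the compounds shown here, replacing 3,4,5-trimethoxyphenyl with 4-cyanophenyl gives the first step beyond the scatter at this place, a modest one (a 2.2-fold higher number from compound 1 to compound 3 (0.35 log units; beyond the scatter)), although compound 2 stays within the scatter of both compound 1 and compound 3. No measurement at hand accounts for this step. As far as these compounds go, whether an aminophenyl or a carboxyphenyl group at this place would shift the number further remains open.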